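Isobutyl to cyclohexyl on the sulfur

The source may report more compounds than this note shows. Statements on the series, on what has been measured and on what is new or still open speak of the compounds shown alone.

In a functional assay on MT4 cells (Homo sapiens) for cytotoxicity (a lower number here means that less compound is tolerated, a higher number that more compound is tolerated), compound 1 (`Cc1c(O)nc(SC(C)C)nc1C(C)c1c(F)cccc1F`) gives 200000 nM. Compound 2 (`Cc1c(O)nc(SCC(C)C)nc1C(C)c1c(F)cccc1F`) gives > 200000 nM, which is a limit of the assay and not a number. Compound 2 therefore has a position only as a limit, with no exact value to start from.

Compound 3 (`Cc1c(O)nc(SC2CCCCC2)nc1C(C)c1c(F)cccc1F`) keeps the shared core and carries cyclohexyl in place of isobutyl on a sulfur. Going by the values given here, only one measured step bears on this change, the swap of isopropyl for isobutyl on the same sulfur. From the compounds shown here alone, it reads a number no lower from compound 1 to compound 2 (the limit leaves the size open), so it shows no fall in the tolerated concentration, but its size stays open.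

On the strength of that step, no change beyond the scatter is expected, and the estimated move is an at least 1.1-fold lower number from compound 2 to compound 3 (0.04 log units; that floor lies within the scatter). Compound 3 is expected at 180000 nM, with an estimated range of 70000 nM to 300000 nM.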

Compound 3, half-maximal cytotoxic concentration: > 200000 nM
Compound 3 ended at the assay's limit (the forecaster's own chance of this, stated with the estimate: 50%); at least 1.1-fold (0.04 log units) between middle value and limit.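

Compound 3 shows that a ring on this sulfur, and not only an open chain, leaves the tolerated concentration at a limit of the assay in this assay. The swap of isopropyl for cyclohexyl on the sulfur reads a number no lower from compound 1 to compound 3 (the limit leaves the size open), so this larger change, too, shows no fall. Any step between the isobutyl and cyclohexyl compounds cannot be read, since neither compound 2 nor compound 3 has an exact value: the limit of > 200000 nM in this assay, at which 2 of the 3 values shown sit.

From the compounds shown here alone, how far either compound lies past that limit stays open. Also open, going by these compounds, is whether a phenyl ring or a chain ending in an amine on this sulfur would bring the number down to a readable value.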